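The source may hold more compounds than are shown below. What is called first, only, known or untested is meant among the compounds shown, and "the series" means these compounds.

Going by the values given here, in a physicochemical assay for lipophilicity, measured as octanol-water partition (a higher number here means a more lipophilic compound, a lower number a more polar compound), compound 2 (`COc1ccc(/C=N/c2ccccc2C(=O)NNc2ccnc3cc(Cl)ccc23)cc1`) gives 5 and stands lowest of the two numbers so far, while compound 1 (`O=C(NNc1ccnc2cc(Cl)ccc12)c1ccccc1/N=C/c1cccc(Cl)c1Cl`) gives 6.1 as its nearest neighbour. Compound 3 (`O=C(NNc1ccnc2cc(Cl)ccc12)c1ccccc1/N=C/c1ccc([N+](=O)[O-])cc1`) has not been measured yet. It carries nitro in place of methoxy on an aromatic carbon, para to a large group (nitro in place of methoxy on an aromatic carbon), so 4-methoxyphenyl becomes 4-nitrophenyl. Among the compounds with values here, only one measured step bears on this change, and it is large: 4-methoxyphenyl in place of 2,3-dichlorophenyl gave a number 1.10 log units lower from compound 1 to compound 2 (beyond the scatter) as the measured difference. That step removed a dichlorophenyl group, and nothing of the kind changes here, so a step of that size is not expected. Within the data shown here, no measurement yet shows what a nitro group does. The expected step is small and within the scatter, an estimated a number 0.10 log units lower from compound 2 to compound 3 (within the scatter) in all. For compound 3 the estimate is 4.9 with an expected range from 4.4 to 5.5 as the likely span.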

Compound 3, partition coefficient: 4.58
Beside the measured number, compound 3's estimate is 0.32 log units above it; measured number inside the range.
By their numbers in this assay, from the lowest: compound 3; then compound 2; then compound 1.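

In this assay the swap of nitro for methoxy gives a number 0.42 log units lower from compound 2 to compound 3 (beyond the scatter) and so shows that the group on this aromatic carbon, para to a large group, moves the number even when the 2,3-dichlorophenyl ring plays no part in the comparison. Placing 4-nitrophenyl where 2,3-dichlorophenyl stood gives a number 1.52 log units lower from compound 1 to compound 3 (beyond the scatter) and adds a second case, alongside compound 2, in which a ring with one group in that place stands well under compound 1. Nothing available here accounts for either step. As far as these compounds go, whether an amine or a carboxylic acid on the same aromatic carbon would bring the number lower still remains open. From the compounds shown here alone, it is also open what a single chlorine or a longer chain such as ethoxy would give there.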